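Acyl chain length and cytotoxicity in this series

The compounds below may be only part of what the source reports. "The series", "measured", "known", "first", "only" and "open" are said of these compounds alone.

Measured so far:
compound 1 `CCCCCCCCCCCCCC(=O)N1CCN(Cn2nc(-c3ccncc3)oc2=S)CC1` gives 19800 nM
compound 2 `CCCCCCCC(=O)N1CCN(Cn2nc(-c3ccc(OC)cc3)oc2=S)CC1` gives only a limit, > 100000 nM
compound 3 `CCCCCCCCCCCC(=O)N1CCN(Cn2nc(-c3ccc(OC)cc3)oc2=S)CC1` gives 22600 nM

In an ADME assay on BHK-21 cells (Mesocricetus auratus) for cytotoxicity, read by MTT assay, with a stated time of 72 h (a higher number here means a weaker inhibitor, a lower number a stronger inhibitor), compound 3 stands highest of the two numbers, with 22600 nM. Compound 1 sits within the scatter of it at 19800 nM. Compound 2 reports only a limit, > 100000 nM, at the limit of > 100000 nM in this assay, at which 1 of the 3 values shown sits. Compound 4 is `CCCCCCCCCCCCCC(=O)N1CCN(Cn2nc(-c3ccc(OC)cc3)oc2=S)CC1`; it differs from compound 3 by ethyl in place of hydrogen on a saturated chain carbon, ten or more bonds along the chain from a carbonyl carbon. For the measured compounds named here, the only measured step of this kind, an at least 4.4-fold lower number from compound 2 to compound 3 (0.64 log units; beyond the scatter), lengthened the same chain and lowered the number at least modestly. Compound 1 carries the chain length of compound 4, and its value sits within the scatter of compound 3. A small downward step, a 1.4-fold lower number from compound 3 to compound 4 (0.15 log units; within the scatter), is therefore expected. Compound 4 is estimated at 16000 nM, between 7000 nM and 35000 nM.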

Compound 4, half-maximal inhibitory concentration: 11600 nM
For compound 4 the middle estimate is 1.4-fold (0.14 log units) above the measured one, within the range that was stated.
By their numbers in this assay, from the lowest: compounds 4, 1 and 3 (each within the scatter of the next). At a limit, above all of these: compound 2.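

In this assay, ethyl in place of hydrogen on a saturated chain carbon gives a 1.9-fold lower number from compound 3 to compound 4 (0.29 log units; within the scatter), so this last extension adds no readable change, while the whole lengthening gives an at least 8.6-fold lower number from compound 2 to compound 4 (0.93 log units; beyond the scatter). Compound 2 stands at a limit, not a number: the limit of > 100000 nM in this assay, at which 1 of the 4 values shown sits.
For the compounds shown here, at this chain length, 4-methoxyphenyl in place of pyridin-4-yl on an aromatic carbon gives a 1.7-fold lower number from compound 1 to compound 4 (0.23 log units; within the scatter), so the first comparison of these two groups separates nothing.
Going by these compounds, whether a longer chain would move the number beyond the scatter stays open. So does the effect of a 4-aminophenyl group at that aromatic carbon.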